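The compounds below may be only part of what the source reports. "The series", "measured", "known", "first", "only" and "open" are said of these compounds alone.

In a functional assay on CCRF-CEM cells (Homo sapiens) for antiproliferative activity, read by cell counting, with a stated time of 2 days (on this read-out lower numbers stand for stronger inhibition and higher numbers for weaker inhibition), compound 1 `COc1ccc(Nc2nc(N)c(C(=O)c3ccccc3)s2)cc1` gives 300 nM. Compound 2 `Nc1nc(Nc2ccc(Cl)cc2)sc1C(=O)c1ccccc1` reads > 10000 nM, which is a limit of the assay and not a number. Its standing on the numbers shown is therefore only (the limit of > 10000 nM in this assay, at which 1 of the 2 values shown sits).

Compound 3 `Nc1nc(Nc2ccc(F)cc2)sc1C(=O)c1ccccc1` is not yet measured. It keeps the shared core and differs from compound 2 in one place: fluoro in place of chloro on an aromatic carbon. In words, this is fluoro in place of chloro on an aromatic carbon, 4-chlorophenyl to 4-fluorophenyl.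

Within the data shown here, one measured step bears on this place, an at least 33-fold higher number from compound 1 to compound 2 (1.52 log units; beyond the scatter). That step is large and beyond the scatter, and it swaps chloro for methoxy on the same aromatic carbon. Among the measured compounds shown here, it shows that this place can move the read-out in this assay, but no measured compound carries fluoro there, and the starting point of the new step is only a limit.

A modest move to a lower number is expected, and a second result at the limit remains quite possible. The estimated step is an at least 2.0-fold lower number from compound 2 to compound 3 (0.30 log units; that floor lies within the scatter). The estimate for compound 3 is 5000 nM, with an expected range from 800 nM to 20000 nM.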

Compound 3, half-maximal inhibitory concentration: > 10000 nM
Compound 3: a limit, no number; the forecaster's own chance of this, stated with the estimate: 45%; middle value at least 2.0-fold (0.30 log units) away from the limit.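

In this assay compound 3 reads > 10000 nM, a limit of the assay and not a number, so a second group on this aromatic carbon now ends at the limit, with fluoro behaving like chloro as far as the assay can tell. Methoxy remains the only group shown at this place that gives a measurable value, and replacing it with fluoro gives an at least 33-fold higher number from compound 1 to compound 3 (1.52 log units; beyond the scatter), so the loss seen with chloro is not confined to that one group. The step between chloro and fluoro cannot be read, and the series now stands as follows: the limit of > 10000 nM in this assay, at which 2 of the 3 values shown sit.

Whether a hydroxyl, an ethoxy or a dimethylamino group on this carbon would keep a measurable value, as methoxy does, remains open, so the compounds shown cannot separate a specific benefit of methoxy from a wider tolerance for groups of that kind. Going by these compounds, how far compound 2 and compound 3 lie beyond the limit, and whether they differ from each other at all, also remains open.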